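Cyclopropyl for Isobutyl on the Benzimidazole Carbon

The source may report more compounds than this note shows. Statements on the series, on what has been measured and on what is new or still open speak of the compounds shown alone.

The two measured compounds in an assay on membranes from HEK293 cells for displacement of a labelled ligand from Type-2 angiotensin II receptor (Homo sapiens), read by radioligand binding (a lower number here means a stronger inhibitor, a higher number a weaker inhibitor), are compound 1, `CCCc1ccc(S(=O)(=O)NC(=O)OCCC(F)(F)C(F)(F)F)c(-c2ccc(Cn3c(C(C)(C)C)nc4ccccc43)cc2)c1`, and compound 2, `CCCCOC(=O)NS(=O)(=O)c1ccc(CCC)cc1-c1ccc(Cn2c(CC(C)C)nc3ccccc32)cc1`. In this assay compound 1 gives 6 nM. In this assay compound 2 gives 19 nM, the higher of the two numbers, and the gap to compound 1 lies beyond the scatter; since the two differ in several places at once, nothing further can be read from that pair.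

The next compound is compound 3, `CCCCOC(=O)NS(=O)(=O)c1ccc(CCC)cc1-c1ccc(Cn2c(C3CC3)nc3ccccc32)cc1`. It differs from compound 2 in one place: cyclopropyl in place of isobutyl on an aromatic carbon

Going by the values given here, no measured pair shows this change. With only the value of compound 2 as anchor, the step from compound 2 to compound 3 is expected to stay within the scatter, with no clear direction, a 1.3-fold lower number from compound 2 to compound 3 (0.10 log units; within the scatter). Compound 3 is therefore expected to give about 15 nM in this assay, within a range from 5 nM to 45 nM.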

Compound 3, inhibition constant: 31 nM
Estimate against measurement, compound 3: 2.1-fold (0.32 log units) below; low and high end bracket the measured number.
By their numbers in this assay, from the lowest: compound 1; then compounds 2 and 3 (each within the scatter of the next).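

In this assay, cyclopropyl in place of isobutyl on this aromatic carbon between two ring nitrogen atoms gives a 1.6-fold higher number from compound 2 to compound 3 (0.21 log units; within the scatter). Going by these compounds alone, this is the first single-place comparison at this position, and it shows that a three-membered ring of carbon only, with 3 heavy atoms where isobutyl has 4, reads the same as the open branched chain within the scatter. Nothing available explains this result.

As far as these compounds go, whether an amine, a carboxylic acid, a methyl group or a longer chain on this carbon would read the same remains open. From the compounds shown here alone, it is also open whether the same exchange would give a similar step on the background of compound 1, which differs from compound 2 in several places.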